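Amide replacement on a shared core with both comparators at the limit

The compounds below may be only part of what the source reports. "The series", "measured", "known", "first", "only" and "open" are said of these compounds alone.

The series rests on a shared core carrying two sulfonyl groups, varied only at the amide attached to the carbonyl carbon. Compound 1 `CCN(CC)S(=O)(=O)c1ccc(S(=O)(=O)N2CCC[C@@H](C(=O)N3CCC(O)CC3)C2)cc1` bears a 4-hydroxypiperidin-1-yl amide. In a functional assay on MIA PaCa-2 cells (Homo sapiens) for inhibition, read by MTT assay, with a stated time of 3 days (on this read-out higher numbers stand for weaker inhibition and lower numbers for stronger inhibition), compound 1 gives > 10000 nM, which is a limit of the assay and not a number. Compound 2 `CCN(CC)S(=O)(=O)c1ccc(S(=O)(=O)N2CCC[C@@H](C(=O)NC3CCOCC3)C2)cc1` carries an (oxan-4-yl)amino group instead. In this assay compound 2 gives > 10000 nM, again a limit rather than a number. The step that the two limits leave unreadable from compound 1 to compound 2 therefore cannot be read, because the limit of > 10000 nM in this assay, at which 2 of the 2 values shown sit, shows both values sitting at the same limit. Compound 3 `CCN(CC)S(=O)(=O)c1ccc(S(=O)(=O)N2CCC[C@@H](C(=O)N3CCC(C(F)(F)F)CC3)C2)cc1` is the next change: 4-(trifluoromethyl)piperidin-1-yl in place of (oxan-4-yl)amino on a carbonyl carbon. Among the compounds with values here, no measured step bears on this change, since both comparators are limits and their difference is unreadable. Compound 2 stands at the limit, and without any readable step the author expects compound 3 to stay near it, with a step that the limit leaves unreadable from compound 2 to compound 3 expected to be small or unreadable in either direction. Compound 3 is therefore estimated in this assay at 12000 nM, within a range from 3000 nM to 40000 nM, most likely reported again only as a limit.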

Compound 3, half-maximal inhibitory concentration: > 10000 nM
Compound 3 gave a limit, no number; the forecaster's own chance of this, stated with the estimate: 70%; the middle value lies beyond the limit too.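

In this assay compound 3 gives > 10000 nM, again a limit and not a number, so the steps from compound 1 and from compound 2 to compound 3 cannot be read: the limit of > 10000 nM in this assay, at which 3 of the 3 values shown sit.

The compounds shown leave open how these three amides on the shared core rank against one another in this assay.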